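Nitrogen substituent change in the naphthyl aminopyridine series

A few compounds are considered here, and "the series" means these few. Any claim that something is new, unique, unknown or untested is made for them only; others in the source may bear on it.

Measured so far in an assay for inhibition of leukotriene C4 synthase (Homo sapiens), read by LC-MS, with stated times of 15 min and 30 min; a lower number here means a stronger inhibitor, a higher number a weaker inhibitor:
compound 1, `COc1cc(N(CC2CC2)c2ccc(Cl)c3ccccc23)cnc1C(=O)[C@H]1C[C@@H]1C(=O)O`: 1.41 nM
compound 2, `COc1cc(N(CC2CC2)c2ccc(F)c3ccccc23)cnc1C(=O)[C@H]1C[C@@H]1C(=O)O`: 0.758 nM

Among the compounds with values here, the only step so far is a 1.9-fold lower number from compound 1 to compound 2 (0.27 log units; within the scatter), which exchanges a halogen on the aromatic ring. Compound 2 carries the lowest of the two numbers, with compound 1 nearest at a gap that is within the scatter, so no order between the two is claimed.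

Compound 3, `COc1cc(N(CC(C)C)c2ccc(F)c3ccccc23)cnc1C(=O)[C@H]1C[C@@H]1C(=O)O`, differs from compound 2 by isopropyl in place of cyclopropyl on a saturated chain carbon bound to a nitrogen on an aromatic ring. Within the data shown here, no measured pair touches the group on the nitrogen, so the halogen step gives no direct guidance; it only shows that a small change elsewhere on the shared core stayed within the scatter. With nothing pointing either way, the expected step is a 1.3-fold higher number from compound 2 to compound 3 (0.12 log units; within the scatter), that is, none beyond the scatter. Compound 3 is therefore estimated at 1 nM, with a range of 0.4 nM to 2.5 nM in this assay.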

Compound 3, half-maximal inhibitory concentration: 0.381 nM
Estimate against measurement, compound 3: 2.6-fold (0.42 log units) above, outside the stated range (below it).
By their numbers in this assay, from the lowest: compounds 3, 2 and 1 (each within the scatter of the next, the first and the last beyond it).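

In this assay, within the data shown here, this is the only measured pair that touches the group on the nitrogen, and cyclopropylmethyl to isobutyl reads as a 2.0-fold lower number from compound 2 to compound 3 (0.30 log units; within the scatter) with the printed gap within the scatter. The three-membered ring of compound 2 is therefore not required at this position for a low number, since the open-chain isobutyl of compound 3, with the same count of heavy atoms, gives 0.381 nM in this assay. Nothing on hand accounts for this result, so the step stands without an explanation.

Isobutyl is shown only with fluoro on the aromatic carbon, so it remains open whether the same group with chloro there would read alike. On these data alone, it is also open how a longer chain such as n-butyl, or a chain ending in an amine or a carboxylic acid, would read on this nitrogen.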